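This account rests on a few compounds, and the source may have more. Where it says the series, first, only, none or still open, it means among the compounds named here.

Compound 2 `CC(C(=O)NCc1ccc(C(F)(F)F)cc1C1CCCCC1)c1ccc(NS(C)(=O)=O)c(F)c1` gives 0.6 nM in an assay on CHO cells for antagonist activity at transient receptor potential cation channel subfamily V member 1 (Homo sapiens), read by FLIPR (on this read-out lower numbers stand for stronger inhibition and higher numbers for weaker inhibition), the lower of the two numbers shown, though its gap to compound 1 `CCC1CCN(c2cc(C(F)(F)F)ccc2CNC(=O)C(C)c2ccc(NS(C)(=O)=O)c(F)c2)CC1`, which gives 0.7 nM, is within the scatter. The step of a 1.2-fold lower number from compound 1 to compound 2 (0.07 log units; within the scatter) confirms this. Compound 3 `CC(C(=O)NCc1ccc(C(F)(F)F)cc1-c1cccc(Cl)c1)c1ccc(NS(C)(=O)=O)c(F)c1` carries the change (3-chlorophenyl in place of cyclohexyl on an aromatic carbon). Going by the values given here, the only measured step that bears on it is that one, where one ring took the place of another on an aromatic carbon without any move beyond the scatter, so a similarly small move is expected in this assay. Compound 3 is therefore estimated at 1 nM, within 0.3 nM to 4 nM, an expected step of a 1.7-fold higher number from compound 2 to compound 3 (0.22 log units; within the scatter).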

Compound 3, inhibition constant: 1 nM
Estimate against measurement, compound 3: no gap at the digits printed, and the stated range covers the measured number.
By their numbers in this assay, from the lowest: compounds 2, 1 and 3 (each within the scatter of the next).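

In this assay, the position now also accepts an aromatic ring carrying a chlorine: a 1.7-fold higher number from compound 2 to compound 3 (0.22 log units; within the scatter), and a 1.4-fold higher number from compound 1 to compound 3 (0.15 log units; within the scatter). Across the three rings shown, aromatic or not, carbon-only or containing nitrogen, the ring type therefore does not separate the compounds on this read-out. Nothing available explains why these rings read alike.

From the compounds shown here alone, whether this position needs a ring at all remains open, as a methyl, an amine or a carboxylic acid could read differently. An unsubstituted phenyl would be needed to show what the chlorine contributes.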